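Replacing 1-methyl-1H-pyrazol-4-yl with tert-butyl on compound 3

This account rests on a few compounds, and the source may have more. Where it says the series, first, only, none or still open, it means among the compounds named here.

Measured in a functional assay on B16-F0 cells (Mus musculus) for inhibition, read by CCK-8 assay, with a stated time of 48 h; a lower number here means a stronger inhibitor, a higher number a weaker inhibitor:
Compound 1 `COc1cc(-c2ccnc3cc(-c4ccc(Cl)cc4)nn23)cc(OC)c1OC`: 4090 nM
Compound 2 `COc1cc(-c2ccnc3cc(-c4cccc(C#N)c4)nn23)cc(OC)c1OC`: > 10000 nM
Compound 3 `COc1cc(-c2ccnc3cc(-c4ccc(-c5cnn(C)c5)cc4)nn23)cc(OC)c1OC`: 1240 nM

The reading for compound 2, > 10000 nM, is a limit of the assay and not a number. Compound 3 has the lower of the two actual numbers, and the step linking it to the other is a 3.3-fold lower number from compound 1 to compound 3 (0.52 log units; beyond the scatter).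

Compound 4 `COc1cc(-c2ccnc3cc(-c4ccc(C(C)(C)C)cc4)nn23)cc(OC)c1OC` carries tert-butyl in place of 1-methyl-1H-pyrazol-4-yl on an aromatic carbon.

For the measured compounds named here, two measured steps bear on this. The closer one is the step already given, which changes the same aromatic carbon. The other, with 3-cyanophenyl in place of 4-chlorophenyl, is an at least 2.4-fold higher number from compound 1 to compound 2 (0.38 log units; beyond the scatter). Neither involves tert-butyl. Removing the group that separates compound 3 from compound 1 might undo part of a 3.3-fold lower number from compound 1 to compound 3 (0.52 log units; beyond the scatter), so a modest rise is expected in this assay. The expected change is a 2.0-fold higher number from compound 3 to compound 4 (0.30 log units; within the scatter). Compound 4 is estimated at 2500 nM, with an expected range from 800 nM to 7500 nM.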

Compound 4, half-maximal inhibitory concentration: > 10000 nM
Compound 4 was reported as a limit; the forecaster's own chance of this, stated with the estimate: 12%; at least 4.0-fold (0.60 log units) between middle value and limit.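

In this assay, the change at this aromatic carbon gives an at least 8.0-fold higher number from compound 3 to compound 4 (0.90 log units; beyond the scatter), so the result with 1-methyl-1H-pyrazol-4-yl does not carry over to tert-butyl. Tert-butyl also falls behind chloro on the same carbon, with an at least 2.4-fold higher number from compound 1 to compound 4 (0.38 log units; beyond the scatter), which gives an order across three groups where the earlier compounds offered only a comparison of two. The reading for compound 4 is a limit, so each of these steps gives only a smallest size: the limit of > 10000 nM in this assay, at which 2 of the 4 values shown sit.

The step from compound 2 to compound 4 cannot be read, as both readings are limits. The compounds shown also leave open whether the ring or the hydrogen-bond acceptors of 1-methyl-1H-pyrazol-4-yl account for the difference, and how an amine or a carboxylic acid on this carbon would read.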